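Trimming methoxy groups on a pyrazole chalcone series

The compounds below may be only part of what the source reports. "The series", "measured", "known", "first", "only" and "open" are said of these compounds alone.

Measured compounds:
compound 1 `COc1ccc(-c2cc(/C=C/C(=O)c3ccc(N)cc3)[nH]n2)cc1`: -80%
compound 2 `COc1cc(-c2cc(/C=C/C(=O)c3ccc(N)cc3)[nH]n2)cc(OC)c1OC`: -94%
compound 3 `COc1ccc(C(=O)/C=C/c2cc(-c3cc(OC)c(OC)c(OC)c3)n[nH]2)cc1`: -6%

Compound 2 stands lowest of the three numbers in a functional assay on SNB-19 cells (Homo sapiens) for cytotoxicity, read by sulforhodamine B assay, with a stated time of 48 h, tested at 100 uM; on this read-out lower numbers stand for a stronger effect and higher numbers for a weaker effect at the one concentration tested. Its nearest neighbour is compound 1, and the step of a number 88 percentage points higher from compound 2 to compound 3 (beyond the scatter) is the largest gap in the set. Compound 4 `COc1ccc(-c2cc(/C=C/C(=O)c3ccc(N)cc3)[nH]n2)cc1OC` differs from compound 2 in one place: hydrogen in place of methoxy on an aromatic carbon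

For the measured compounds named here, the only step measured in the set, a number 88 percentage points higher from compound 2 to compound 3 (beyond the scatter), concerns methoxy in place of amino and does not bear on this change. Going by the values given here, compound 1 and compound 2 differ by two methoxy groups, not one, so no single step between them is given; their values show that the compound with fewer methoxy groups sits somewhat higher in this assay. For compound 4 the removal of one methoxy is therefore expected to give a small upward step, a number 8 percentage points higher from compound 2 to compound 4 (within the scatter), which is expected to stay close to the scatter. The estimate for compound 4 is -86%, with a range from -100% to -62%.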

Compound 4, a percentage reported as activity, at one concentration (the size of the read-out at that concentration, not a potency): -91%
For compound 4 the middle estimate is 5 percentage points above the measured one; the measured number falls inside the stated range.
By their numbers in this assay, from the lowest: compounds 2 and 4 (each within the scatter of the next); then compound 1; then compound 3.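

In this assay, replacing this methoxy group, ortho to a methoxy group and meta to a large group, with hydrogen gives a number 3 percentage points higher from compound 2 to compound 4 (within the scatter), so the two compounds cannot be told apart at the one concentration tested. Methoxy in place of hydrogen on an aromatic carbon does give a step beyond the scatter in the other pair now available, a number 11 percentage points lower from compound 1 to compound 4 (beyond the scatter), so the same kind of change counts in one pair and cannot be seen in the other. Nothing given here explains this difference between the two steps.

As far as these compounds go, it remains open whether a hydroxyl group, a fluorine atom or an ethoxy group at this place would stay within the scatter of methoxy and hydrogen. From the compounds shown here alone, it also remains open whether methoxy in place of amino would give as large a step on compound 4 as a number 88 percentage points higher from compound 2 to compound 3 (beyond the scatter).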